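Piperidine for Tetrahydroisoquinoline: From Measured Pair to Prediction

A few compounds are considered here, and "the series" means these few. Any claim that something is new, unique, unknown or untested is made for them only; others in the source may bear on it.

Of the compounds shown here, three have been measured in a functional assay on HCT-116 cells (Homo sapiens) for inhibition, read by MTT assay, with a stated time of 72 h, tested at 20 uM; a lower number here means less inhibition, a higher number more inhibition at the concentration tested (going by the name of the read-out). Compound 3 `CN(c1ccc(Oc2ncnc3sccc23)cc1)c1nccc(N2CCc3ccccc3C2)n1` gives 57.7%, and compound 1 `CN(c1ccc(Oc2ncnc3sccc23)cc1)c1nccc(N2CCCCC2)n1` gives 52.2%. The two differ in one place: piperidin-1-yl in place of 1,2,3,4-tetrahydroisoquinolin-2-yl on an aromatic carbon. That change produced a number 5.5 percentage points lower from compound 3 to compound 1 (within the scatter), so the two values sit together. Compound 2 `c1ccc2c(c1)CCN(c1ccnc(Nc3ccc(Oc4ncnc5ccsc45)cc3)n1)C2` gives 40.9%, the lowest of the three numbers, beyond the scatter from both of the others. How the core of compound 2 differs from that of compound 3 is not broken down here.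

Compound 4 `c1cc(N2CCCCC2)nc(Nc2ccc(Oc3ncnc4ccsc34)cc2)n1` has not yet been measured in this assay. It relates to compound 2 as compound 1 relates to compound 3: piperidin-1-yl in place of 1,2,3,4-tetrahydroisoquinolin-2-yl on an aromatic carbon. The place of the change is the same in both pairs, so this is the same change. Because the measured pair gave a number 5.5 percentage points lower from compound 3 to compound 1 (within the scatter), the step from compound 2 to compound 4 is expected to be similar and small, at about a number 3.9 percentage points lower from compound 2 to compound 4 (within the scatter). Compound 4 is therefore estimated to give roughly 37%, plausibly between 22% and 52%.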

Compound 4, a percentage reported as inhibition, at one concentration (the size of the read-out at that concentration, not a potency): 61.5%
For compound 4 the middle estimate is 24.5 percentage points below the measured one; measured number above the stated range.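

In this assay, replacing 1,2,3,4-tetrahydroisoquinolin-2-yl with piperidin-1-yl on the core of compound 2 gave a number 20.6 percentage points higher from compound 2 to compound 4 (beyond the scatter), an outcome unlike that of the same change on the core of compound 3. The two steps do not agree: the same change on two cores in this assay, a number 5.5 percentage points lower (within the scatter) from compound 3 to compound 1 and a number 20.6 percentage points higher (beyond the scatter) from compound 2 to compound 4, 26.1 percentage points apart, beyond the scatter of two such steps. This shows that, in this series, the result of this change on one core cannot simply be carried over to the other, although two pairs neither explain the disagreement nor give a rule for any further core.

The compounds shown leave open how other amines at the same place, such as morpholin-4-yl or an open-chain dimethylamino group, would behave on these two cores, and whether any of them would show the same disagreement between the cores. With readings at a single concentration, they also leave open whether the step from piperidin-1-yl to 1,2,3,4-tetrahydroisoquinolin-2-yl would look the same at other concentrations.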